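The source may report more compounds than this note shows. Statements on the series, on what has been measured and on what is new or still open speak of the compounds shown alone.

Measured so far, in a physicochemical assay for permeability, using PAMPA, with a stated time of 4 h, at pH 7.4, tested at 50 uM; a higher number here means that the compound crosses the layer faster, a lower number that the compound crosses the layer more slowly:

Compound 1, `Cc1c(CCCC(=O)O)c2cccc(/C=C/c3ccc(OCCCCc4ccccc4)cc3)c2n1CC(=O)O`: in this assay compound 1 gives < 0.05 10^-6 cm/s, which is a limit of the assay rather than a number.
Compound 2, `Cc1c(CCCC(=O)O)c2cccc(/C=C/c3ccc(OCCCCc4cc(F)c(F)c(F)c4F)cc3)c2n1CC(=O)O`: in this assay compound 2 gives 0.3 10^-6 cm/s.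

Going by the values given here, compound 2 therefore holds the only actual number among the values shown; the other value is a limit (the limit of < 0.05 10^-6 cm/s in this assay, at which 1 of the 2 values shown sits). Among the compounds with values here, the one measured step, an at least 6.0-fold higher number from compound 1 to compound 2 (0.77 log units; beyond the scatter), sets the only reference for the change at this part of the molecule.

Compound 3, `Cc1c(CCCC(=O)O)c2cccc(/C=C/c3ccc(OCCCCc4c(F)ccc(F)c4F)cc3)c2n1CC(=O)O`, differs from compound 2 by 2,3,6-trifluorophenyl in place of 2,3,4,5-tetrafluorophenyl on a saturated chain carbon, four bonds along the chain from an oxygen on an aromatic ring. The measured step bears on it only loosely, since it compared phenyl with a fluorinated phenyl, whereas here one fluorinated phenyl is exchanged for another. A step of a 1.2-fold lower number from compound 2 to compound 3 (0.08 log units; within the scatter) is expected, within the scatter. Compound 3 is estimated at 0.25 10^-6 cm/s, with a range from 0.08 10^-6 cm/s to 0.7 10^-6 cm/s.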

Compound 3, apparent permeability: 2.6 10^-6 cm/s
For compound 3 the middle estimate is 10-fold (1.02 log units) below the measured one; measured number above the stated range.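

Compound 3 shows that in this assay the result at this position, on a saturated chain carbon, four bonds along the chain from an oxygen on an aromatic ring, does not depend only on whether the phenyl carries fluorine: exchanging one fluorinated phenyl for another gives an 8.7-fold higher number from compound 2 to compound 3 (0.94 log units; beyond the scatter), a step beyond the scatter. Against the unsubstituted phenyl, the 2,3,6-trifluorophenyl group gives an at least 52-fold higher number from compound 1 to compound 3 (1.71 log units; beyond the scatter), a larger gap than the earlier step from the same starting point. The value of compound 1 is a limit and not a number, so this gap has only a lower bound: the limit of < 0.05 10^-6 cm/s in this assay, at which 1 of the 3 values shown sits.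

The two fluorinated groups differ in both the number and the placing of their fluorines, and the compounds shown do not separate the two. Where a pentafluorophenyl group or a longer chain would fall remains open.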